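The source may report more compounds than this note shows. Statements on the series, on what has been measured and on what is new or still open speak of the compounds shown alone.

Measured so far:
compound 1 `CN(C)CCn1cnnc1-c1cc(Oc2ccc(NC(=O)N/N=C/c3ccc(Cl)cc3)cc2F)ccn1` — 320 nM
compound 2 `CN(C)CCn1cnnc1-c1cc(Oc2ccc(NC(=O)N/N=C/c3ccc(O)c(O)c3)cc2F)ccn1` — 1930 nM
compound 3 `CN(C)CCn1cnnc1-c1cc(Oc2ccc(NC(=O)N/N=C/c3cc(Br)c(O)c(Br)c3)cc2F)ccn1` — 3760 nM

In a functional assay on NCI-H460 cells (Homo sapiens) for cytotoxicity, read by MTT assay, with a stated time of 72 h (a lower number here means a stronger inhibitor, a higher number a weaker inhibitor), compound 3 carries the highest number of the three. Compound 2 is nearest to it, a 1.9-fold higher number from compound 2 to compound 3 (0.29 log units; within the scatter); compound 1 is furthest, a 12-fold higher number from compound 1 to compound 3 (1.07 log units; beyond the scatter). Compound 4 `CN(C)CCn1cnnc1-c1cc(Oc2ccc(NC(=O)N/N=C/c3ccc(O)c(Br)c3)cc2F)ccn1` differs from compound 3 by hydrogen in place of bromo on an aromatic carbon. Within the data shown here, no measured step removes a single bromo, so only a 1.9-fold higher number from compound 2 to compound 3 (0.29 log units; within the scatter) bears on it, and that step is within the scatter; a 6.0-fold higher number from compound 1 to compound 2 (0.78 log units; beyond the scatter) spans the 4-chlorophenyl and 3,4-dihydroxyphenyl variants and does not apply here. Compound 4 is therefore expected to land close to compound 3. Only a small step is expected for compound 4, a 1.3-fold lower number from compound 3 to compound 4 (0.13 log units; within the scatter). The estimate for compound 4 is 2800 nM, range 1400 nM to 5600 nM.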

Compound 4, half-maximal inhibitory concentration: 430 nM
Compound 4: the middle estimate sits 6.5-fold (0.81 log units) above what was measured, outside the stated range (below it).
By their numbers in this assay, from the lowest: compounds 1 and 4 (each within the scatter of the next); then compounds 2 and 3 (each within the scatter of the next).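

In this assay, among these compounds, this aromatic carbon ortho to a hydroxy group is sensitive to bromo versus hydrogen, with an 8.7-fold lower number from compound 3 to compound 4 (0.94 log units; beyond the scatter), a step the earlier compounds gave no sign of. The other substituent matters too: with bromo in place of hydroxy there is a 4.5-fold lower number from compound 2 to compound 4 (0.65 log units; beyond the scatter). The 3-bromo-4-hydroxyphenyl and 4-chlorophenyl variants cannot be told apart, with a 1.3-fold higher number from compound 1 to compound 4 (0.13 log units; within the scatter). Nothing available explains these steps. From the compounds shown here alone, whether a methoxy group or an amine at this carbon would track with hydrogen or with bromo stays open.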